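A few compounds are considered here, and "the series" means these few. Any claim that something is new, unique, unknown or untested is made for them only; others in the source may bear on it.

In a functional assay on KM12 cells (Homo sapiens) for cytotoxicity, read by sulforhodamine B assay, with a stated time of 48 h (a higher number here means that more compound is tolerated, a lower number that less compound is tolerated), the measured compounds give these numbers:
Compound 1 `Nc1nc(Cl)c2ncn(Cc3ccc(CCl)cc3)c2n1` gives 57500 nM.
Compound 2 `ClCc1cccc(Cn2cnc3c(Cl)nc(Cl)nc32)c1` gives 7940 nM.
Compound 3 `ClCc1ccc(Cn2cnc3c(Cl)nc(Cl)nc32)cc1` gives 5750 nM.

Compound 1 and compound 3 differ in one place: amino in place of chloro on an aromatic carbon. That single change made the step of a 10-fold higher number from compound 3 to compound 1 (1.00 log units; beyond the scatter), so the cells tolerate more of compound 1 than of compound 3. Compound 2 and compound 3 are built from the same atoms joined differently; how the two cores differ is not broken down here, and their values in this assay lie within the usual scatter of each other.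

Compound 4 `Nc1nc(Cl)c2ncn(Cc3cccc(CCl)c3)c2n1` has not yet been measured in this assay. It differs from compound 2 by amino in place of chloro on an aromatic carbon. The place of this change is described in the same words as for the change from compound 3 to compound 1, so it is the same change, now made on the core of compound 2. Because the change from compound 3 to compound 1 gave a 10-fold higher number from compound 3 to compound 1 (1.00 log units; beyond the scatter), the expected step is a 9.4-fold higher number from compound 2 to compound 4 (0.98 log units; beyond the scatter). Compound 4 is therefore estimated at 75000 nM, with a likely range from 30000 nM to 200000 nM.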

Compound 4, concentration lethal to 50% of the cells: 37200 nM
Estimate against measurement, compound 4: 2.0-fold (0.30 log units) above, within the range that was stated.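

Putting amino in place of chloro on an aromatic carbon again let the cells tolerate more compound in this assay with a 4.7-fold higher number from compound 2 to compound 4 (0.67 log units; beyond the scatter) on the core of compound 2, in the same direction as the earlier step on the core of compound 3. Set side by side, the two steps are no further apart than repeated measurements of such steps would be, so the change carried over between these two cores: the same change on two cores in this assay, a 10-fold higher number (1.00 log units; beyond the scatter) from compound 3 to compound 1 and a 4.7-fold higher number (0.67 log units; beyond the scatter) from compound 2 to compound 4, 2.1-fold (0.33 log units) apart, within the scatter of two such steps

Among these compounds, this rests on only two cores built from the same atoms, so it does not show that the step would hold on a core of another kind, and it does not explain why the number rises.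

Going by these compounds, whether a methylamino or methoxy group in place of the chloro would give a step of similar size remains open. Also open, on these data alone, is how the step would behave if the chloromethyl group shared by all four compounds gave way to a hydroxymethyl group or a longer chain.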